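A Methyl Group Moves from One Position to Another

The compounds below may be only part of what the source reports. "The series", "measured", "known", "first", "only" and "open" are said of these compounds alone.

Three compounds built on one shared core have been examined in an ADME assay on HEK293 cells (Homo sapiens) for inhibition, read by MTT assay, with a stated time of 48 h, tested at 25 uM; a lower number here means less inhibition, a higher number more inhibition at the concentration tested (going by the name of the read-out). Compound 1 `Fc1ccccc1-n1cc(COc2ccc3c(c2)CCC3)nn1` gives 21% there. Compound 2 `Clc1ccc(-n2cc(COc3ccc4c(c3)CCC4)nn2)cc1` returns "not determined" (no result reported), so no number is available for it. Compound 3 `Cc1ccc(-n2cc(COc3ccc4c(c3)CCC4)nn2)cc1` likewise returns "not determined" (no result reported). Among the measured compounds shown here, compound 3 therefore stands without a value, and the only number in the set comes from compound 1.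

Compound 4 `Cc1cccc(-n2cc(COc3ccc4c(c3)CCC4)nn2)c1` keeps the same atoms as compound 3 but joins them differently: 3-methylphenyl in place of 4-methylphenyl on an aromatic nitrogen. For the measured compounds named here, no step between two measured compounds is available, so the size and direction of the change cannot be read from the data; nothing beyond the usual scatter is assumed. Since compound 1 gives 21%, compound 4 is expected to show roughly 20%, estimated between 5% and 40%.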

Compound 4, a percentage reported as inhibition, at one concentration (the size of the read-out at that concentration, not a potency): 23.4%
Compound 4: middle estimate off by 3.4 percentage points, on the low side, within the range that was stated.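

Among the compounds shown here, compound 4 gives the first comparison in this set: in this assay there is a number 2.4 percentage points higher from compound 1 to compound 4 (within the scatter), so swapping 2-fluorophenyl for 3-methylphenyl on this aromatic nitrogen leaves the reading within the usual scatter. Compound 3 has no number, so the move from 4-methylphenyl to 3-methylphenyl itself cannot be read. No measurement here offers an explanation for the result.

From the compounds shown here alone, what remains open is whether the reading stays this flat with a different group on this nitrogen, such as a phenyl ring carrying an amine or a carboxylic acid, or a longer chain.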